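The compounds below may be only part of what the source reports. "The series", "measured", "known", "first", "only" and "open" are said of these compounds alone.

Notes on the series. Compound 1 `CN(C)C(=O)c1cc2cnc(Nc3ccc(S(=O)(=O)NCCCN=C=S)cc3)nc2n1C1CCCC1` and compound 2 `CN(C)C(=O)c1cc2cnc(Nc3ccc(C(=O)NCCCCCN=C=S)cc3O)nc2n1C1CCCC1` share the same core and were both run in a functional assay on A549 cells (Homo sapiens) for inhibition, read by CCK-8 assay, with a stated time of 72 h, tested at 10 uM; a higher number here means a stronger effect of the compound at the concentration tested, a lower number a weaker effect. In this assay, for the measured compounds named here, compound 1 gives 102%, the higher of the two numbers so far, and compound 2 gives 30.7%, a gap well beyond the usual scatter; the two differ in several places at once, so no single change accounts for it. Compound 3 `CN(C)C(=O)c1cc2cnc(Nc3ccc(NC(=O)CCCN=C=S)cc3)nc2n1C1CCCC1` is not yet measured. It differs from compound 1 in one place: a group of 9 heavy atoms (5 carbon, 2 nitrogen, 1 oxygen, 1 sulfur; no ring) in place of a group of 10 heavy atoms (4 carbon, 2 nitrogen, 2 oxygen, 2 sulfur; no ring), on an aromatic carbon. The isothiocyanate end is kept, and the change sits on an aromatic carbon of a six-membered aromatic ring of carbon only, para to a large group. Going by the values given here, with no single-point step measured, the size of the effect is uncertain; a moderate drop from compound 1 is expected, a number 22 percentage points lower from compound 1 to compound 3 (beyond the scatter). For compound 3 in this assay the estimate is 80%, within 45% to 100%.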

Compound 3, a percentage reported as inhibition, at one concentration (the size of the read-out at that concentration, not a potency): 102%
Beside the measured number, compound 3's estimate is 22 percentage points below it, and the stated range ends below it.
By their numbers in this assay, from the lowest: compound 2; then compounds 1 and 3 (each within the scatter of the next).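

In this assay, for the compounds shown here, the only step in one place so far reads no change at the digits printed from compound 1 to compound 3 (within the scatter) with the isothiocyanate end kept, so the read-out does not separate the group of 10 heavy atoms from the group of 9 heavy atoms at this aromatic carbon, para to a large group. The exchange is therefore tolerated at the single concentration tested, although a read-out at one concentration is not a potency and any difference at lower concentrations stays out of view. No measurement on these compounds accounts for this result.

Open, as far as these compounds go, is whether an amine or a carboxylic acid in place of the isothiocyanate would keep the read-out. Also open, from the compounds shown here alone, is whether a longer chain on the same aromatic carbon would do so.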